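This account rests on a few compounds, and the source may have more. Where it says the series, first, only, none or still open, it means among the compounds named here.

Measured compounds:
- Compound 1, `Nc1cc(N)c2nc(-c3ccccc3)c(NCc3ccc(Cl)c(Cl)c3)nc2c1`: in a functional assay on MCF7 cells (Homo sapiens) for inhibition, read by sulforhodamine B assay, with a stated time of 48 h (a higher number here means that more compound is tolerated, a lower number that less compound is tolerated), compound 1 gives < 100000 nM, which is a limit of the assay and not a number.
- Compound 2, `Nc1cc(N)c2nc(-c3ccccc3)c(Sc3ccc(F)cc3)nc2c1`: in this assay compound 2 gives < 100000 nM, again a limit rather than a number.
- Compound 3, `COc1cc(CNc2nc3cc(N)cc(N)c3nc2-c2ccccc2)cc(OC)c1OC`: in this assay compound 3 gives < 50200 nM, also a limit.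

All three compounds share the same core and differ only in the group attached to it. None of them has a true number in this assay; every value is a limit. Compound 2 sits at the limit of < 100000 nM in this assay, at which 2 of the 3 values shown sit, and so no exact point for it is known. The third value sits at the limit of < 50200 nM in this assay, at which 1 of the 3 values shown sits, which is likewise only a limit.

The compound to be measured next is compound 4, `Nc1cc(N)c2nc(-c3ccccc3)c(Sc3ccc(Cl)c(Cl)c3)nc2c1`. It differs from compound 2 in one place: 3,4-dichlorophenyl in place of 4-fluorophenyl on a sulfur.

With no measured step between any two compounds shown, there is no basis to expect a change in this assay beyond the usual scatter, in either direction. The step from compound 2 to compound 4 is therefore expected to be small, a step that the limit leaves unreadable from compound 2 to compound 4. For compound 4 in this assay the estimate is 30000 nM, within a range from 5000 nM to 100000 nM, with a fair chance that only a limit is reported again.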

Compound 4, concentration lethal to 50% of the cells: < 100000 nM
Compound 4: no number, only a limit; the forecaster's own chance of this, stated with the estimate: 50%; the middle value lies beyond the limit too.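

In this assay, compound 2 and compound 4 both give a limit and not a number, so the change to 3,4-dichlorophenyl in place of 4-fluorophenyl on a sulfur cannot be read as a step: the limit of < 100000 nM in this assay, at which 3 of the 4 values shown sit.

The compounds shown leave open the true value of each compound in this assay, and whether the group on the sulfur changes that value at all.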